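Replacing the aryl group on sulfur in compound 1

The compounds below may be only part of what the source reports. "The series", "measured", "known", "first", "only" and "open" are said of these compounds alone.

In a functional assay on HeLa cells (Homo sapiens) for inhibition, read by CCK-8 assay, with a stated time of 72 h, tested at 8 uM (on this read-out lower numbers stand for less inhibition of growth and higher numbers for more inhibition of growth at the one concentration tested), the measured compounds read as follows:
compound 1 `Cc1cc(C)cc(SCc2ccc(/C=C/C(=O)Nc3ccccc3N)cc2)c1` gives 3.39%
compound 2 `Nc1ccccc1NC(=O)/C=C/c1ccc(CSc2cccc(F)c2)cc1` gives 18.6%
compound 3 `Cc1ccc(SCc2ccc(/C=C/C(=O)Nc3ccccc3N)cc2)cc1` gives 21.7%

Compound 1 has the lowest number of the three, and both other compounds lie above it by more than the usual scatter. Compound 4 `Nc1ccccc1NC(=O)/C=C/c1ccc(CSc2ccc(F)cc2)cc1` has not been measured yet. Its difference from compound 1 (4-fluorophenyl in place of 3,5-dimethylphenyl on a sulfur) is 4-fluorophenyl in place of 3,5-dimethylphenyl on a sulfur.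

Two measured steps make the same kind of replacement on that sulfur. With a 3-fluorophenyl group there is a number 15.2 percentage points higher from compound 1 to compound 2 (beyond the scatter) and the step is modest. With a 4-methylphenyl group there is a number 18.3 percentage points higher from compound 1 to compound 3 (beyond the scatter) and the step is again modest. These two end points barely differ, since a number 3.1 percentage points higher from compound 2 to compound 3 (within the scatter) stays within the scatter. Compound 4 shares its fluorine with compound 2 and the 4-position of its substituent with compound 3, so a similar modest rise seems the fair expectation. Among the measured compounds shown here, only two such steps exist, so the range stays wide. The expected step is a number 16.6 percentage points higher from compound 1 to compound 4 (beyond the scatter) by this estimate. For compound 4 the estimated value in this assay is 20% (expected range 8% to 35%).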

Compound 4, percent growth inhibition at one concentration: 10.4%
The estimate for compound 4 lay 9.6 percentage points above the measured number; the measured number falls inside the stated range.
By their numbers in this assay, from the lowest: compounds 1, 4, 2 and 3 (each within the scatter of the next, the first and the last beyond it).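

In this assay, the 4-fluorophenyl group on this sulfur cannot be told apart from the 3,5-dimethylphenyl group (a number 7 percentage points higher from compound 1 to compound 4 (within the scatter)), so replacing the 3,5-dimethylphenyl group does not always give a change beyond the scatter, as it did for compound 2 and compound 3. The swap of fluoro for methyl on an aromatic carbon does give such a change (a number 11.3 percentage points lower from compound 3 to compound 4 (beyond the scatter)), which shows that the identity of the group on this ring can matter, while the change from 3-fluorophenyl to 4-fluorophenyl cannot be separated from the scatter (a number 8.2 percentage points lower from compound 2 to compound 4 (within the scatter)). Nothing available here bears on the cause of these differences.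

The compounds shown leave open whether a 4-chlorophenyl or 4-methoxyphenyl group on the sulfur would read closer to the 4-methylphenyl group of compound 3 or the 4-fluorophenyl group of compound 4. They also leave open what an unsubstituted phenyl group, or a non-aromatic group such as cyclohexyl or a longer saturated chain, would give at this sulfur.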